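This account rests on a few compounds, and the source may have more. Where it says the series, first, only, none or still open, it means among the compounds named here.

Of the compounds shown here, two have been measured in a functional assay on MGC-803 cells (Homo sapiens) for antiproliferative activity, read by MTT assay, with a stated time of 48 h (a higher number here means a weaker inhibitor, a lower number a stronger inhibitor), so far. Compound 1 `COc1cc(N(Cc2ccccc2)C(=O)CSc2nc3ccccc3s2)cc(OC)c1OC` gives 44300 nM in this assay. Compound 2 `COc1ccc2nc(SCC(=O)N(Cc3ccc(OC)c(O)c3)c3cc(OC)c(OC)c(OC)c3)sc2c1` gives 71 nM in this assay, the lowest of the two numbers; its nearest neighbour is compound 1, whose number is higher by a gap that lies beyond the scatter. Compound 3 `COc1ccc(CN(C(=O)CSc2nc3cc(Br)ccc3s2)c2cc(OC)c(OC)c(OC)c2)cc1O` has not yet been measured. It differs from compound 2 in one place: a group of 10 heavy atoms (7 carbon, 1 nitrogen, 1 sulfur, 1 bromine; one five-membered aromatic ring with 2 hetero atoms, one six-membered aromatic ring of carbon only) in place of a group of 11 heavy atoms (8 carbon, 1 nitrogen, 1 oxygen, 1 sulfur; one five-membered aromatic ring with 2 hetero atoms, one six-membered aromatic ring of carbon only), on a sulfur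

No step between measured compounds bears on this change, so there is nothing shown that would make a large step expected. On that basis, the step from compound 2 to compound 3 in this assay is expected to be small, a 1.4-fold higher number from compound 2 to compound 3 (0.15 log units; within the scatter), a shift of no clear direction and likely within the scatter. Compound 3 is therefore estimated to give 100 nM in this assay, with a range from 30 nM to 400 nM.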

Compound 3, half-maximal inhibitory concentration: 372 nM
Estimate against measurement, compound 3: 3.7-fold (0.57 log units) below, within the range that was stated.
By their numbers in this assay, from the lowest: compound 2; then compound 3; then compound 1.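

In this assay, replacing the 6-methoxy-1,3-benzothiazol-2-yl group on the sulfur with the bromine-bearing group gives a 5.2-fold higher number from compound 2 to compound 3 (0.72 log units; beyond the scatter), a modest step. This shows that the group on this sulfur matters to the read-out: two groups of nearly the same heavy-atom count, one carrying oxygen and the other bromine, are told apart by the assay, though compound 3 still gives 372 nM. Nothing measured here explains the step.

Going by these compounds, the step swaps methoxy for bromine in a single change, so how much of it belongs to losing the one and how much to gaining the other remains open. On these data alone, how the number would respond to a chlorine, a trifluoromethyl or an amine on this group also remains open.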